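The source may hold more compounds than are shown below. What is called first, only, known or untested is meant among the compounds shown, and "the series" means these compounds.

Measured compounds:
Compound 1, `CCCSc1nc(N/N=C/c2cccnc2)c2nnn(Cc3ccccc3)c2n1`: > 64000 nM, a limit of the assay
Compound 2, `C#CCSc1nc(N/N=C(\C)c2ccccc2O)c2nnn(Cc3ccccc3)c2n1`: 5250 nM
Compound 3, `CCCSc1nc(N/N=C/c2cccs2)c2nnn(Cc3ccccc3)c2n1`: > 64000 nM, a limit of the assay

In a functional assay on ECa-109 cells (Homo sapiens) for antiproliferative activity, read by MTT assay, with a stated time of 72 h (on this read-out lower numbers stand for stronger inhibition and higher numbers for weaker inhibition), compound 3 gives only a limit, > 64000 nM. Compound 1 also gives only a limit, > 64000 nM. Going by the values given here, the single step between measured compounds, a step that the two limits leave unreadable from compound 1 to compound 3, stays unreadable because both values sit at the limit of > 64000 nM in this assay, at which 2 of the 3 values shown sit. Compound 4, `CCCSc1nc(N/N=C(\C)c2ccccc2O)c2nnn(Cc3ccccc3)c2n1`, differs from compound 3 in one place: a group of 10 heavy atoms (8 carbon, 1 nitrogen, 1 oxygen; one six-membered aromatic ring of carbon only) in place of a group of 7 heavy atoms (5 carbon, 1 nitrogen, 1 sulfur; one five-membered aromatic ring with 1 hetero atom), on a nitrogen on an aromatic ring. Among the compounds with values here, no measured step covers this change. Compound 2 carries the same entering group on the shared core and gives 5250 nM in this assay, a number rather than a limit. Compound 4 is therefore expected to give 6000 nM, between 2000 nM and 20000 nM. The expected step of an at least 10-fold lower number from compound 3 to compound 4 (1.02 log units; beyond the scatter) points toward stronger inhibition.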

Compound 4, half-maximal inhibitory concentration: 11100 nM
Compound 4: the middle estimate sits 1.9-fold (0.27 log units) below what was measured; low and high end bracket the measured number.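

In this assay, replacing the group on a nitrogen on an aromatic ring gives an at least 5.7-fold lower number from compound 3 to compound 4 (0.76 log units; beyond the scatter) and an at least 5.7-fold lower number from compound 1 to compound 4 (0.76 log units; beyond the scatter), so this position can move a compound off the assay limit. Both sizes are only minimum sizes, as each starting compound gives a limit and not a number: the limit of > 64000 nM in this assay, at which 2 of the 4 values shown sit. Ethyl in place of ethynyl on a saturated chain carbon bound to a sulfur gives a 2.1-fold higher number from compound 2 to compound 4 (0.33 log units; beyond the scatter), a modest loss that still leaves a measurable number. Going by these compounds, whether a longer chain or a carboxylic acid at that same place would keep this activity remains open.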